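This account rests on a few compounds, and the source may have more. Where it says the series, first, only, none or still open, it means among the compounds named here.

Working notes on the series. Compound 1 (`COc1cc(NC(C)CCCN2C(=O)[C@H](C)NC2(C)C)c2ncccc2c1`) gives 42300 nM in a functional assay on MCF7 cells (Homo sapiens) for antiproliferative activity, read by sulforhodamine B assay, with a stated time of 48 h (a higher number here means a weaker inhibitor, a lower number a stronger inhibitor), and compound 2 (`COc1cc(NC(C)CCCNC(=O)CN2C(=O)[C@H](C)NC2(C)C)c2ncccc2c1`) gives 38300 nM there, so the two values lie within the scatter of each other. Within the data shown here, compound 3 (`COc1cc(NC(C)CCCNC(C)=O)c2ncccc2c1`) has no measurement yet. It differs from compound 2 by a single change (hydrogen in place of 2,2,4-trimethyl-5-oxoimidazolidin-1-yl on a saturated chain carbon bound to a carbonyl carbon): hydrogen in place of 2,2,4-trimethyl-5-oxoimidazolidin-1-yl on a saturated chain carbon bound to a carbonyl carbon. Among the measured compounds shown here, no measured step covers this change, so any step in this assay remains an expectation, and none beyond the scatter is expected in either direction. For the measured compounds named here, the only guide is that compound 1 at 42300 nM and compound 2 at 38300 nM stay within the scatter despite their different chains. The estimated change (a 1.2-fold higher number from compound 2 to compound 3 (0.07 log units; within the scatter)) stays inside that scatter. For compound 3 the estimated value is 45000 nM with an expected range from 15000 nM to 120000 nM as the working figure.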

Compound 3, half-maximal inhibitory concentration: 57300 nM
Compound 3: the middle estimate sits 1.3-fold (0.10 log units) below what was measured; the measured number falls inside the stated range.
By their numbers in this assay, from the lowest: compounds 2, 1 and 3 (each within the scatter of the next).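

The imidazolidinone ring turns out not to be what sets the level in this assay: hydrogen in place of 2,2,4-trimethyl-5-oxoimidazolidin-1-yl on a saturated chain carbon bound to a carbonyl carbon gives a 1.5-fold higher number from compound 2 to compound 3 (0.17 log units; within the scatter) and so leaves a plain acetamide chain with no step beyond the scatter. Acetamido in place of the same ring on the saturated chain carbon gives a 1.4-fold higher number from compound 1 to compound 3 (0.13 log units; within the scatter) and is also within the scatter, so neither of the two ring-bearing chains separates from the ring-free one. No supporting data bear on this result.

As far as these compounds go, whether an amine or a carboxylic acid on that chain carbon, or a longer chain, would move the number beyond the scatter stays open. All three compounds share one core, so the contribution of the core itself also remains unresolved.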